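The compounds below may be only part of what the source reports. "The series", "measured", "known", "first", "only" and "open" are said of these compounds alone.

Working notes on the series. Compound 1 `CN(C)C(=O)c1cc2cnc(Nc3ccc(C(=O)NCCCCN=C=S)cc3)nc2n1C1CCCC1` gives 55.2% in a functional assay on NCI-H1299 cells (Homo sapiens) for inhibition, read by CCK-8 assay, with a stated time of 72 h, tested at 1 uM; a lower number here means a weaker effect, a higher number a stronger effect of the compound at the concentration tested. Among the three measured compounds it stands second highest: compound 2 `CN(C)C(=O)c1cc2cnc(Nc3ccc(C(=O)NCCCCCCCN=C=S)cc3)nc2n1C1CCCC1` gives 75.7%, and compound 3 `CN(C)C(=O)c1cc2cnc(Nc3ccc(C(=O)NCCCCN=C=S)cc3F)nc2n1C1CCCC1` gives 28.7%. Both steps from compound 1 lie beyond the scatter: a number 20.5 percentage points higher from compound 1 to compound 2 (beyond the scatter), and a number 26.5 percentage points lower from compound 1 to compound 3 (beyond the scatter).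

Compound 4 `CN(C)C(=O)c1cc2cnc(Nc3ccc(NC(=O)CCCCN=C=S)cc3)nc2n1C1CCCC1` is not yet measured. Relative to compound 1 the change is a group of 10 heavy atoms (6 carbon, 2 nitrogen, 1 oxygen, 1 sulfur; no ring) in place of a group of 10 heavy atoms (6 carbon, 2 nitrogen, 1 oxygen, 1 sulfur; no ring), on an aromatic carbon; the two compounds hold the same atoms, joined differently. Neither measured step bears directly on this change. Among the compounds with values here, the step to compound 2 puts a group of 6 heavy atoms in place of a group of 3 on a saturated chain carbon, the step to compound 3 puts fluoro in place of hydrogen on an aromatic carbon, and no measured pair has the same atoms joined differently. The two measured steps only show that a single change in this part of the molecule shifts the read-out by modest amounts in either direction, so a modest step in either direction is possible here and no direction is favoured. The estimated value for compound 4 in this assay is 50%, with a range from 25% to 75%. The expected step is a number 5.2 percentage points lower from compound 1 to compound 4 (within the scatter).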

Compound 4, a percentage reported as inhibition, at one concentration (the size of the read-out at that concentration, not a potency): 58.6%
For compound 4 the middle estimate is 8.6 percentage points below the measured one; low and high end bracket the measured number.
By their numbers in this assay, from the lowest: compound 3; then compounds 1 and 4 (each within the scatter of the next); then compound 2.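

In this assay the step is a number 3.4 percentage points higher from compound 1 to compound 4 (within the scatter), so joining the same atoms differently in the group on the aromatic carbon, para to a large group, leaves compound 1 and compound 4 indistinguishable. The earlier steps shown here to compound 2 and compound 3 both lay beyond the scatter; this result adds a change in the group that does not separate the two compounds at the concentration tested. No measured information explains this result.

The compounds shown leave open whether the rejoined group would stay level with the original group if it carried a longer chain, as in compound 2, or if fluoro were added, as in compound 3. They also leave open how either arrangement would read with an amine or a carboxylic acid at the chain end.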